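A Bromo Substituent Tested Against a Methyl Gain

A few compounds are considered here, and "the series" means these few. Any claim that something is new, unique, unknown or untested is made for them only; others in the source may bear on it.

In a functional assay on the whole organism (strain Wistar) for inhibition, with Rattus norvegicus as the target, read by paw edema, with stated times of 30 min and 3 h, at a dose of 50 mg/kg by the oral route (a lower number here means less inhibition, a higher number more inhibition at the dose given (going by the name of the read-out)), compound 1 `Nc1cc(-c2ccc(Cl)cc2)nc2cc(-c3ccccc3)nn12` gives 28% and compound 2 `Cc1ccc(-c2cc3nc(-c4ccc(Cl)cc4)cc(N)n3n2)cc1` gives 64.6%. Among the measured compounds shown here, compound 2 stands highest of the two numbers, and the only measured step, a number 36.6 percentage points higher from compound 1 to compound 2 (beyond the scatter), shows how far a single substituent moved the read-out here. Compound 3 `Nc1cc(-c2ccc(Cl)cc2)nc2cc(-c3ccc(Br)cc3)nn12` differs from compound 2 by bromo in place of methyl on an aromatic carbon, on an aromatic carbon of a six-membered aromatic ring of carbon only, para to a large group; cut one bond further out the change reads 4-methylphenyl to 4-bromophenyl. For the measured compounds named here, no measured step covers bromo in place of methyl, so the expectation rests on the fact that compound 2 still carries a substituent at the position that was bare in compound 1. Compound 3 is therefore expected to stay in the range of compound 2 or fall somewhat, the step being estimated as a number 9.6 percentage points lower from compound 2 to compound 3 (within the scatter). The estimate for compound 3 in this assay is 55%, between 35% and 75%.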

Compound 3, a percentage reported as inhibition, in the whole organism at one dose (the size of the read-out at that dose, not a potency): 56.1%
Beside the measured number, compound 3's estimate is 1.1 percentage points below it; measured number inside the range.
By their numbers in this assay, from the lowest: compound 1; then compounds 3 and 2 (each within the scatter of the next).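

In this assay, bromo in place of hydrogen on the aromatic carbon gives a number 28.1 percentage points higher from compound 1 to compound 3 (beyond the scatter) and so shows that the gain at this position does not belong to methyl alone. Bromo in place of methyl gives a number 8.5 percentage points lower from compound 2 to compound 3 (within the scatter) and leaves the two substituents indistinguishable in this read-out, which the single earlier step could not show. Nothing at hand bears on what lies behind these numbers.

Only methyl and bromo are shown against hydrogen at this position, so it remains open whether an amine, a carboxylic acid or a longer chain such as butyl would keep the number up or lose it. Also open, on these data alone, is whether the same order of substituents would hold on the shared core at other doses.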